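The source may hold more compounds than are shown below. What is called first, only, known or untested is meant among the compounds shown, and "the series" means these compounds.

Measured compounds:
compound 1, `O=[N+]([O-])c1cc(-c2nc(-c3cccs3)no2)cc(O)c1O`, 29.6%
compound 2, `Cc1cc(-c2cc(-c3cc(O)c(O)c([N+](=O)[O-])c3)on2)on1`, 32.4%

In a functional assay on the whole organism (liver, strain NMRI) for inhibition, with Mus musculus as the target, with a stated time of 3 h, at a dose of 3 mg/kg by the oral route (on this read-out lower numbers stand for less inhibition and higher numbers for more inhibition at the one dose given (going by the name of the read-out)), compound 2 gives 32.4%, the higher of the two numbers measured, while compound 1 gives 29.6%; the gap between them lies within the scatter, so the two compounds cannot be told apart on this read-out. Compound 3 `Cc1ccc(-c2cc(-c3cc(O)c(O)c([N+](=O)[O-])c3)on2)c(Cl)n1` differs from compound 2 in one place: 2-chloro-6-methylpyridin-3-yl in place of 3-methyl-1,2-oxazol-5-yl on an aromatic carbon. Among the measured compounds shown here, no step between measured compounds that differ in one place is available, so the size of such a change is unknown here. Since the two measured compounds, despite differing in the group at this position, sit within the scatter of each other, compound 3 is expected to show a step of a number 1.4 percentage points lower from compound 2 to compound 3 (within the scatter), no larger than the scatter in either direction. Compound 3 is therefore estimated at 31% in this assay, with a range from 16% to 46%.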

Compound 3, a percentage reported as inhibition, in the whole organism at one dose (the size of the read-out at that dose, not a potency): 21.6%
For compound 3 the middle estimate is 9.4 percentage points above the measured one; the measured number falls inside the stated range.
By their numbers in this assay, from the lowest: compounds 3, 1 and 2 (each within the scatter of the next, the first and the last beyond it).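

In this assay, putting 2-chloro-6-methylpyridin-3-yl in place of 3-methyl-1,2-oxazol-5-yl, on an aromatic carbon next to the ring nitrogen of the five-membered aromatic ring, gives a number 10.8 percentage points lower from compound 2 to compound 3 (beyond the scatter), so the read-out does respond to the group at this position. The change swaps a five-membered aromatic ring with two hetero atoms for a six-membered aromatic ring that carries a chlorine and a methyl, and this single step cannot show which of these differences goes with the lower number. Nothing measured here bears on why the number falls.

Going by these compounds, it remains open whether the chlorine matters apart from the ring that carries it. On these data alone, it is also open how an amine or a carboxylic acid at this position would read in this assay at the one dose given.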